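The compounds below may be only part of what the source reports. "The series", "measured", "known", "first", "only" and "open" are said of these compounds alone.

In an assay on isolated protein with malate dehydrogenase, mitochondrial (Sus scrofa) as the target (on this read-out higher numbers stand for weaker inhibition and lower numbers for stronger inhibition), compound 2 `O=C(O)c1cnc2cc(OCCc3ccccc3)ccc2c1O` gives 38000 nM, the highest of the two numbers measured; compound 1 `O=C(O)c1cnc2cc(OCCc3ccc(Br)cc3)ccc2c1O` gives 2510 nM. Within the data shown here, the one measured step, a 15-fold higher number from compound 1 to compound 2 (1.18 log units; beyond the scatter), is the only guide for compound 3 `O=C(O)c1cnc2cc(OCc3ccc(Cl)c(Cl)c3)ccc2c1O`, which carries 3,4-dichlorophenyl in place of benzyl on a saturated chain carbon bound to an oxygen on an aromatic ring. Among the measured compounds shown here, because the loss of a bromo atom gave a 15-fold higher number from compound 1 to compound 2 (1.18 log units; beyond the scatter), the entry of two chlorine atoms is expected to bring the number down again, though the shorter link to the aromatic ring has no measured counterpart and widens the uncertainty. Compound 3 is therefore estimated at 6000 nM, within a range of 1500 nM to 25000 nM, an expected step of a 6.3-fold lower number from compound 2 to compound 3 (0.80 log units; beyond the scatter).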

Compound 3, half-maximal inhibitory concentration: 4790 nM
Compound 3: middle estimate off by 1.3-fold (0.10 log units), on the high side; low and high end bracket the measured number.
By their numbers in this assay, from the lowest: compounds 1 and 3 (each within the scatter of the next); then compound 2.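

In this assay, 3,4-dichlorophenyl in place of benzyl at this place gives a 7.9-fold lower number from compound 2 to compound 3 (0.90 log units; beyond the scatter), so a second halogen-bearing group also gives a lower number than the group without halogen. Set against 4-bromobenzyl, the same group gives a 1.9-fold higher number from compound 1 to compound 3 (0.28 log units; within the scatter), so the two halogen-bearing groups cannot be told apart here. Nothing available accounts for either step. Still open, as far as these compounds go, is how a 4-chlorophenyl or a 4-methoxyphenyl group would read at this place, and whether a longer chain would change the number.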